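Swapping the Sulfinyl Chain for a Dimethylamino Chain

This account rests on a few compounds, and the source may have more. Where it says the series, first, only, none or still open, it means among the compounds named here.

Compound 1, `N=c1sc2cc(OC(F)(F)F)ccc2n1Cc1ccccc1`: in a functional assay on the whole organism with Rattus norvegicus as the target (on this read-out higher numbers stand for an effect only at larger amounts of compound and lower numbers for an effect already at smaller amounts), compound 1 gives > 10 mg/kg, which is a limit of the assay and not a number.
Compound 2, `C[S+]([O-])Cn1c(=N)sc2cc(OC(F)(F)F)ccc21`: in this assay compound 2 gives 2.3 mg/kg.
Compound 3, `C[S+]([O-])CCn1c(=N)sc2cc(OC(F)(F)F)ccc21`: in this assay compound 3 gives 1.1 mg/kg.

Compound 3 stands at the lowest of the two numbers shown; the nearest is compound 2, and the step of a 2.1-fold lower number from compound 2 to compound 3 (0.32 log units; beyond the scatter) separates them. Compound 4, `CN(C)CCn1c(=N)sc2cc(OC(F)(F)F)ccc21`, differs from compound 3 in one place: a group of 3 heavy atoms (2 carbon, 1 nitrogen; no ring) in place of a group of 3 heavy atoms (1 carbon, 1 oxygen, 1 sulfur; no ring), on a saturated chain carbon, two bonds along the chain from an aromatic nitrogen.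

Within the data shown here, three measured steps touch the same chain on the aromatic nitrogen. The steps of an at least 4.3-fold lower number from compound 1 to compound 2 (0.63 log units; beyond the scatter) and an at least 9.0-fold lower number from compound 1 to compound 3 (0.95 log units; beyond the scatter) replace a benzene ring with a short chain, and the step of a 2.1-fold lower number from compound 2 to compound 3 (0.32 log units; beyond the scatter) lengthens that chain. Among the measured compounds shown here, none of them exchanges the sulfur-bearing group for a nitrogen-bearing one, so no measured step tells the direction of the change in compound 4. A step within the scatter is therefore expected: a 1.4-fold higher number from compound 3 to compound 4 (0.13 log units; within the scatter). Compound 4 is estimated at 1.5 mg/kg, with a range from 0.5 mg/kg to 5 mg/kg.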

Compound 4, dose for half-maximal effect: 2.3 mg/kg
Estimate against measurement, compound 4: 1.5-fold (0.19 log units) below, and the stated range covers the measured number.
By their numbers in this assay, from the lowest: compound 3; then compounds 2 and 4 (each within the scatter of the next). At a limit, above all of these: compound 1.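

With dimethylamino on this chain, a 2.1-fold higher number from compound 3 to compound 4 (0.32 log units; beyond the scatter) in this assay shows that the exchange for the sulfur-bearing group has a modest cost at this place, on a saturated chain carbon, two bonds along the chain from an aromatic nitrogen. Measured against the shorter sulfur-bearing chain, the result is no change at the digits printed from compound 2 to compound 4 (within the scatter), so the two chains cannot be told apart in this assay. The gain over the phenyl group also holds for a nitrogen-bearing chain, with an at least 4.3-fold lower number from compound 1 to compound 4 (0.63 log units; beyond the scatter), and compound 1 stands at a limit of the assay and not a number: the limit of > 10 mg/kg in this assay, at which 1 of the 4 values shown sits.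

Going by these compounds, it remains open whether a ring amine such as pyrrolidine or morpholine would do better than dimethylamino on the same chain. On these data alone, a longer chain carrying dimethylamino or a carboxylic acid at its end is equally open.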